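The source may hold more compounds than are shown below. What is called first, only, known or untested is meant among the compounds shown, and "the series" means these compounds.

Two compounds of this series have numbers in a functional assay on MCF7 cells (Homo sapiens) for cytotoxicity, read by MTT assay, with a stated time of 24 h (a higher number here means a weaker inhibitor, a lower number a stronger inhibitor), so far. Compound 1 `CN1CCN(CC(=O)Nc2ccc(-c3nc(-c4ccccc4)c(-c4ccccc4)n3C)cc2)CC1` gives 76.5 ug/mL in this assay, and compound 2 `Cc1ccc(CN2CCN(CC(=O)Nc3ccc(-c4nc(-c5ccccc5)c(-c5ccccc5)n4C)cc3)CC2)cc1` gives 80 ug/mL; compound 2 thus holds the higher of the two numbers, though the gap to compound 1 is within the scatter. Among the measured compounds shown here, the only measured step, a 1.0-fold higher number from compound 1 to compound 2 (0.02 log units; within the scatter), changes a different part of the molecule. Compound 3 `Cn1c(-c2ccc(NC(=O)CN3CCN(Cc4ccc(Cl)cc4)CC3)cc2)nc(-c2ccccc2)c1-c1ccccc1` differs from compound 2 by chloro in place of methyl on an aromatic carbon. For the measured compounds named here, no measured step bears directly on this exchange, so no shift beyond the scatter is expected in this assay. The estimate for compound 3 is 80 ug/mL, range 45 ug/mL to 140 ug/mL, a step of no change at the digits printed from compound 2 to compound 3 (within the scatter) expected.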

Compound 3, half-maximal inhibitory concentration: 21 ug/mL
Beside the measured number, compound 3's estimate is 3.8-fold (0.58 log units) above it; the measured number lies below the stated range.
By their numbers in this assay, from the lowest: compound 3; then compounds 1 and 2 (each within the scatter of the next).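

Chloro in place of methyl on this aromatic carbon moves the number in this assay beyond the scatter (with a 3.8-fold lower number from compound 2 to compound 3 (0.58 log units; beyond the scatter)), the first such shift in the series. The exchange with hydrogen reads the same way for 4-chlorophenyl (with a 3.6-fold lower number from compound 1 to compound 3 (0.56 log units; beyond the scatter)), whereas 4-methylphenyl left compound 2 within the scatter of compound 1, so at this position the outcome depends on which group the aromatic ring carries, not only on the ring being there. As far as these compounds go, whether fluoro, bromo or methoxy at the same place would follow chloro or methyl stays open. What lies behind the shift also stays open, as no measurement shown here addresses it.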